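The source may hold more compounds than are shown below. What is called first, only, known or untested is meant among the compounds shown, and "the series" means these compounds.

Among the compounds with values here, compound 3 `O=C(NC(c1ccc(Cl)cc1)C1CCNCC1)c1ccc2cnccc2c1` gives 190 nM in an assay on isolated protein for inhibition of RAC-alpha serine/threonine-protein kinase (Homo sapiens) (on this read-out higher numbers stand for weaker inhibition and lower numbers for stronger inhibition), the lowest of the three numbers measured so far. Compound 1 `O=C(NC(c1ccc2ccccc2c1)C1CCNCC1)c1ccc2cnccc2c1` gives 400 nM in this assay, and compound 2 `O=C(NC(c1ccc(F)c(F)c1)C1CCNCC1)c1ccc2cnccc2c1` gives 2680 nM. The steps among them read a 2.1-fold lower number from compound 1 to compound 3 (0.32 log units; beyond the scatter), a 14-fold lower number from compound 2 to compound 3 (1.15 log units; beyond the scatter) and a 6.7-fold higher number from compound 1 to compound 2 (0.83 log units; beyond the scatter). Compound 4 `O=C(NC(c1ccc(Cl)c(F)c1)C1CCNCC1)c1ccc2cnccc2c1` differs from compound 3 by fluoro in place of hydrogen on an aromatic carbon. Within the data shown here, no measured step adds a single fluoro while the chloro stays in place; the nearest comparison is the exchange of 3,4-difluorophenyl for 4-chlorophenyl, a 14-fold lower number from compound 2 to compound 3 (1.15 log units; beyond the scatter), which alters two groups at once and so gives only a loose guide. The 4-chlorophenyl of compound 3 is kept whole in compound 4, and one fluoro is added to it, which is a smaller change than either measured exchange on this carbon. A small step in this assay is therefore expected, most likely within the scatter, with a somewhat higher number a little more probable than a lower one. Compound 4 is estimated at 260 nM, in the range 100 nM to 700 nM. The expected step is a 1.4-fold higher number from compound 3 to compound 4 (0.14 log units; within the scatter).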

Compound 4, half-maximal inhibitory concentration: 40 nM
Beside the measured number, compound 4's estimate is 6.5-fold (0.81 log units) above it, outside the stated range (below it).
By their numbers in this assay, from the lowest: compound 4; then compound 3; then compound 1; then compound 2.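

In this assay, fluoro in place of hydrogen on the 4-chlorophenyl, ortho to a chloro group, is not a neutral change: a 4.8-fold lower number from compound 3 to compound 4 (0.68 log units; beyond the scatter). With the 3-fluoro held constant, chloro in place of fluoro also counts for much, a 67-fold lower number from compound 2 to compound 4 (1.83 log units; beyond the scatter), a single-atom exchange that the earlier two-group comparison could not separate. The 4-chloro-3-fluorophenyl also surpasses naphthalen-2-yl, a 10-fold lower number from compound 1 to compound 4 (1.00 log units; beyond the scatter), yet the fluoro does not give a low number in every setting, as compound 2 carries it and still has the highest number of the set.

Nothing shown gives a measured explanation for these steps. On these data alone, whether methyl, methoxy or nitrile in place of this fluoro, or bromo in place of the chloro, would keep the number this low remains open.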